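Cyano in place of chloro on the shared core

A few compounds are considered here, and "the series" means these few. Any claim that something is new, unique, unknown or untested is made for them only; others in the source may bear on it.

Compound 1 `CC1=C(C(=O)OCc2ccccn2)C(c2ccc(Cl)cc2)C2=C(CCCC2=O)N1` stands highest of the two numbers in a physicochemical assay for lipophilicity, measured as octanol-water partition (on this read-out lower numbers stand for lower lipophilicity and higher numbers for higher lipophilicity), giving 2.24. Among the compounds with values here, its nearest neighbour, compound 2 `CC1=C(C(=O)OCc2cccnc2)C(c2ccc(Cl)cc2)C2=C(CCCC2=O)N1`, gives 1.87, and the only measured step, a number 0.37 log units lower from compound 1 to compound 2 (beyond the scatter), concerns the pyridinyl group and not the aromatic carbon changed here. Compound 3 `CC1=C(C(=O)OCc2ccccn2)C(c2ccc(C#N)cc2)C2=C(CCCC2=O)N1` differs from compound 1 by cyano in place of chloro on an aromatic carbon. Within the data shown here, no measured step bears directly on this change, so the expectation rests on the change alone: a step in this assay estimated as a number 1.14 log units lower from compound 1 to compound 3 (beyond the scatter). Compound 3 is therefore expected to give 1.1, within 0.6 to 1.6.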

Compound 3, partition coefficient: 1.73
Compound 3: the middle estimate sits 0.63 log units below what was measured, and the stated range ends below it.
By their numbers in this assay, from the lowest: compounds 3 and 2 (each within the scatter of the next); then compound 1.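

With cyano in place of chloro on the aromatic carbon para to a large group, this assay gives a number 0.51 log units lower from compound 1 to compound 3 (beyond the scatter). Within the data shown here, this shows that the read-out responds to a change at this position as well as at the pyridinyl group, the only place varied among the earlier compounds. Nothing available accounts for the size of this step.

Cyano appears here only with the pyridin-2-yl group, so its step with pyridin-3-yl remains open. Also open, on these data alone, is how an amine or a carboxylic acid on this aromatic carbon would compare with chloro and cyano.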